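The compounds below may be only part of what the source reports. "The series", "measured", "known", "first", "only" and "open" are said of these compounds alone.

Working notes on the urea series in a functional assay on HT-29 cells (Homo sapiens) for cytotoxicity, read by MTT assay, with a stated time of 72 h; a lower number here means a stronger inhibitor, a higher number a weaker inhibitor. Compound 1 `O=C(Nc1ccc(-n2ncc3c(Br)cccc32)cc1)Nc1ccc(Cl)c(C(F)(F)F)c1` gives 4000 nM. Compound 2 `O=C(Nc1ccc(-n2ncc3ccccc32)cc1)Nc1ccc(Cl)c(C(F)(F)F)c1` gives 18200 nM. For the measured compounds named here, the single step between measured compounds, hydrogen in place of bromo on an aromatic carbon, runs a 4.6-fold higher number from compound 1 to compound 2 (0.66 log units; beyond the scatter). Going by the values given here, compound 2 therefore stands at the highest of the two numbers recorded so far, with compound 1 as its only neighbour, lower by that same step.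

Compound 3 `O=C(Nc1ccc(-n2ncc3ccncc32)cc1)Nc1ccc(Cl)c(C(F)(F)F)c1` has not been measured. It differs from compound 2 by a group of 9 heavy atoms (6 carbon, 3 nitrogen; one five-membered aromatic ring with 2 hetero atoms, one six-membered aromatic ring with 1 hetero atom) in place of a group of 9 heavy atoms (7 carbon, 2 nitrogen; one five-membered aromatic ring with 2 hetero atoms, one six-membered aromatic ring of carbon only), on an aromatic carbon. Among the compounds with values here, no measured step bears on this kind of exchange: the one step known, from compound 1 to compound 2, concerns a bromo substituent and a different part of the structure. With nothing directly comparable, the working expectation is no step beyond the scatter, so the step from compound 2 to compound 3 is estimated as a 1.0-fold lower number from compound 2 to compound 3 (0.00 log units; within the scatter). Compound 3 is accordingly expected to give about 18000 nM in this assay, within an estimated range of 6000 nM to 55000 nM. The range is kept wide because the measured step of a 4.6-fold higher number from compound 1 to compound 2 (0.66 log units; beyond the scatter) shows that a small change on this core can move this assay beyond the scatter.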

Compound 3, half-maximal inhibitory concentration: 29500 nM
Beside the measured number, compound 3's estimate is 1.6-fold (0.21 log units) below it, within the range that was stated.
By their numbers in this assay, from the lowest: compound 1; then compounds 2 and 3 (each within the scatter of the next).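

In this assay, a six-membered aromatic ring with 1 hetero atom in place of a six-membered aromatic ring of carbon only gives a 1.6-fold higher number from compound 2 to compound 3 (0.21 log units; within the scatter), so at this place on the aromatic carbon, this exchange within the 1H-indazol-1-yl group does not separate compound 3 from compound 2 by more than repeat measurements would. The wider comparison gives a 7.4-fold higher number from compound 1 to compound 3 (0.87 log units; beyond the scatter), a step that takes away the bromo and brings in the ring nitrogen together, and compound 1 therefore remains apart from both compounds without bromo. No measurement at hand accounts for either step.

The compounds shown leave open whether bromo would keep its step from compound 2 on the ring holding the extra nitrogen, as no compound here carries both, and whether the ring nitrogen would read the same elsewhere in the six-membered ring. They also leave open whether chloro, methoxy or an amine on the carbon that carries bromo in compound 1 would stay with compound 1 or fall in with compound 2 and compound 3.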